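Does One Flipped Stereocentre Move the Partition Value?

The source may report more compounds than this note shows. Statements on the series, on what has been measured and on what is new or still open speak of the compounds shown alone.

In a physicochemical assay for lipophilicity, using the shake flask method, in phosphate buffer, measured as octanol-water partition, at pH 7.4 (a higher number here means a more lipophilic compound, a lower number a more polar compound), compound 1 `CC[C@H](c1ccc(C(=O)O)c(Oc2cccc(Cl)c2)c1OC)N1CCC[C@H](n2cc(C)c(=O)[nH]c2=O)C1` gives -0.13 as its reading, and compound 2 `CC[C@H](c1ccc(C(=O)O)c(Oc2cccc(Cl)c2)c1F)N1CCC[C@H](n2cc(C)c(=O)[nH]c2=O)C1` gives 0.12 as its reading, so the two sit within the usual scatter of each other. That single measured step, a number 0.25 log units higher from compound 1 to compound 2 (within the scatter) for fluoro in place of methoxy on an aromatic carbon, changes a group and not a configuration. Compound 3 `CC[C@@H](c1ccc(C(=O)O)c(Oc2cccc(Cl)c2)c1OC)N1CCC[C@H](n2cc(C)c(=O)[nH]c2=O)C1` is a different kind of neighbour: the two compounds have the same atoms and bonds and differ only in configuration as drawn: 1 of 2 stereo elements differ; a stereocentre at a saturated chain carbon is drawn R in compound 1 and S in compound 3 and nothing enters or leaves. Among the compounds with values here, no measured pair here tests such a change, so the data give no direct guide, and no shift beyond the scatter is expected. The expected step is a number 0.03 log units higher from compound 1 to compound 3 (within the scatter) and it stays inside that scatter. For compound 3 the estimated value in this assay is -0.1 with an expected range from -0.5 to 0.3 around it.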

Compound 3, distribution coefficient: -0.02
The estimate for compound 3 lay 0.08 log units below the measured number; the range from low to high includes it.
By their numbers in this assay, from the lowest: compounds 1, 3 and 2 (each within the scatter of the next).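

In this assay, the configuration at this saturated chain carbon now has a direct test, which the swap of methoxy for fluoro could not provide: the flip from R to S gives a number 0.11 log units higher from compound 1 to compound 3 (within the scatter). For these two methoxy compounds, then, the reading does not separate the two drawn forms at this carbon. The comparison is a clean one, with no other structural difference to weigh: the fact that compounds 1 and 3 differ only in the configuration as drawn

One pair cannot show whether the same flip would stay within the scatter in the fluoro compound 2, or with a nitrile or a trifluoromethyl on that aromatic carbon. From the compounds shown here alone, the second stereo element also remains open, since it is drawn the same way in all three compounds.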